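A Third Amide Variant in a Cell Viability Assay

This account rests on a few compounds, and the source may have more. Where it says the series, first, only, none or still open, it means among the compounds named here.

Measured compounds:
compound 1, `COc1ccc(Cl)cc1N(CC(=O)Nc1cccc2ccccc12)S(=O)(=O)c1ccccc1`: 17400 nM
compound 2, `COc1ccc(CNC(=O)CN(c2cc(Cl)ccc2OC)S(=O)(=O)c2ccccc2)cc1`: > 20000 nM

All numbers here come from a functional assay on SH-SY5Y cells (Homo sapiens), read by MTT assay, with a stated time of 24 h; a lower number here means that less compound is needed, a higher number that more compound is needed for the effect. Compound 1 gives 17400 nM in this assay. For compound 2 the assay reports only a limit, > 20000 nM, and no exact number. Compound 2 therefore stands at the edge of what this assay can measure, as noted in the limit of > 20000 nM in this assay, at which 1 of the 2 values shown sits. For the measured compounds named here, the single measured step, an at least 1.1-fold higher number from compound 1 to compound 2 (0.06 log units; that floor lies within the scatter), is pinned to that limit, so it says nothing beyond the scatter.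

Compound 3, `COc1ccc(Cl)cc1NC(=O)CN(c1cc(Cl)ccc1OC)S(=O)(=O)c1ccccc1`, differs from compound 2 by 5-chloro-2-methoxyphenyl in place of 4-methoxybenzyl on an amide-type nitrogen. Going by the values given here, no measured step swaps one aromatic group for another on that amide nitrogen; the step from compound 1 to compound 2 concerns different groups and gives no direction. Without such guidance, the expected step in this assay from compound 2 to compound 3 is a number no higher from compound 2 to compound 3 (the limit leaves the size open), none beyond the scatter. Compound 3 is thus estimated at 20000 nM in this assay. For compound 3 the expected range runs from 8000 nM to 50000 nM, with a real chance that only a limit is reported again.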

Compound 3, half-maximal effective concentration: > 20000 nM
Compound 3: only a limit was reported; the forecaster's own chance of this, stated with the estimate: 55%; the middle value sits exactly at the limit.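

Compound 3, with 5-chloro-2-methoxyphenyl on the amide-type nitrogen, ends like compound 2 with only a limit rather than an exact number in this assay: the limit of > 20000 nM in this assay, at which 2 of the 3 values shown sit.

Replacing the naphthalen-1-yl group of compound 1 with 5-chloro-2-methoxyphenyl gives an at least 1.1-fold higher number from compound 1 to compound 3 (0.06 log units; that floor lies within the scatter), so this change, like the earlier one to 4-methoxybenzyl, shows nothing beyond the scatter. The step between compound 2 and compound 3 cannot be read, since both carry only a limit, and so these two groups cannot be placed in any order.

Of the three groups shown at this position, only the naphthalen-1-yl of compound 1 comes with an exact number, and the compounds shown do not tell whether any other group here could lower that number by more than the scatter. Also open, as far as these compounds go, is what a group of a different kind on this nitrogen would give, such as a short chain ending in an amine or a carboxylic acid in place of an aromatic ring.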